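Dropping one chloro from a dichlorinated purine benzyl series

The source may report more compounds than this note shows. Statements on the series, on what has been measured and on what is new or still open speak of the compounds shown alone.

Measured compounds:
compound 1, `ClCc1cccc(Cn2cnc3nc(Cl)nc(Cl)c32)c1`: 9330 nM
compound 2, `ClCc1ccc(Cn2cnc3c(Cl)nc(Cl)nc32)cc1`: 20000 nM

Of the compounds shown here, two have been tested in a functional assay on OVCAR-8 cells (Homo sapiens) for cytotoxicity, read by sulforhodamine B assay, with a stated time of 48 h; on this read-out higher numbers stand for weaker inhibition of growth and lower numbers for stronger inhibition of growth. Compound 1 gives 9330 nM, the lower of the two numbers. Compound 2 gives 20000 nM, a number that lies beyond the scatter above that of compound 1, so compound 1 is the stronger growth inhibitor of the pair. Going by the values given here, no pair of measured compounds differs in a single place, so no measured step is available to guide the next change.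

The unmeasured compound 3, `ClCc1cccc(Cn2cnc3ncnc(Cl)c32)c1`, is derived from compound 1 by a single change: hydrogen in place of chloro on an aromatic carbon. The chloro that is lost sits between two ring nitrogen atoms of the shared core, meta to the remaining chloro group.

Among the compounds with values here, with no measured step of the same kind to lean on, the step from compound 1 to compound 3 is expected to be small, if anything a slight weakening of growth inhibition, and it may well stay within the scatter: a 1.3-fold higher number from compound 1 to compound 3 (0.11 log units; within the scatter). Compound 3 is accordingly expected to give about 12000 nM in this assay, with a plausible range from 5000 nM to 30000 nM.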

Compound 3, concentration for 50% growth inhibition: 3090 nM
Beside the measured number, compound 3's estimate is 3.9-fold (0.59 log units) above it; the measured number lies below the stated range.
By their numbers in this assay, from the lowest: compound 3; then compound 1; then compound 2.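

In this assay, the chloro between two ring nitrogen atoms of the shared core proves dispensable for growth inhibition: replacing it with hydrogen gives a 3.0-fold lower number from compound 1 to compound 3 (0.48 log units; beyond the scatter), a modest step in the direction of stronger inhibition of growth. Going by these compounds alone, the earlier compounds offered no step in a single place, so this is the first direct reading of any position, and it shows that on this aromatic carbon hydrogen does better than chloro while the remaining chloro stays in place. No measurement at hand explains why the number falls.

The compounds shown leave open whether hydrogen is the best choice at this position, or whether an amine, a methoxy group or a methyl group there would move the number further in either direction. They also leave open whether the remaining chloro, which sits meta to this position, contributes to growth inhibition, and whether an amine in its place would keep the gain seen with compound 3.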